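Isopropyl to sec-butyl: expected distribution of compound 3

The compounds below may be only part of what the source reports. "The series", "measured", "known", "first", "only" and "open" are said of these compounds alone.

In an in vivo ADME assay on the whole organism (strain Sprague-Dawley) for pharmacokinetics, with Rattus norvegicus as the target (on this read-out lower numbers stand for narrower distribution and higher numbers for wider distribution into tissues), compound 1 (`CC(C)[C@@H]1NC[C@@H](C)Oc2ccccc2CCCNC(=O)[C@@H](Cc2ccc(F)cc2)NC(=O)[C@@H](C)N(C)C1=O`) gives 2 L/kg and compound 2 (`C[C@@H]1C(=O)N[C@H](Cc2ccc(F)cc2)C(=O)NCCCc2ccccc2OCCN[C@@H](C2CC2)C(=O)N1C`) gives 1.4 L/kg with the two values within the scatter of each other. Compound 3 (`CC[C@H](C)[C@@H]1NC[C@@H](C)Oc2ccccc2CCCNC(=O)[C@@H](Cc2ccc(F)cc2)NC(=O)[C@@H](C)N(C)C1=O`) carries one change from compound 1 (methyl in place of hydrogen on a saturated chain carbon, two bonds along the chain from a saturated ring carbon): methyl in place of hydrogen on a saturated chain carbon, two bonds along the chain from a saturated ring carbon. Among the measured compounds shown here, no measured single-site step is available, so the expectation rests on the change alone: no step beyond the scatter in this assay is expected. The expected step is no change at the digits printed from compound 1 to compound 3 (within the scatter) in this estimate. Compound 3 is estimated at 2 L/kg with an expected range from 1.1 L/kg to 3.6 L/kg for the coming measurement.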

Compound 3, volume of distribution at steady state: 2.5 L/kg
Estimate against measurement, compound 3: 1.3-fold (0.10 log units) below; the range from low to high includes it.
By their numbers in this assay, from the lowest: compounds 2, 1 and 3 (each within the scatter of the next).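

Isopropyl to sec-butyl gives the first single-site step in this assay (a 1.3-fold higher number from compound 1 to compound 3 (0.10 log units; within the scatter)), and it stays within the scatter. This position, on a saturated chain carbon, two bonds along the chain from a saturated ring carbon, therefore takes one added methyl with no step beyond the scatter on this read-out. No supporting data bear on why the step has this size. On these data alone, whether a longer chain, an amine or a carboxylic acid at this position would give a step beyond the scatter stays open. A single methyl also leaves open how the same change reads on other members of the series.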